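This account rests on a few compounds, and the source may have more. Where it says the series, first, only, none or still open, it means among the compounds named here.

Measured so far in a functional assay on MDA-MB-231 cells (Homo sapiens) for antiproliferative activity, read by sulforhodamine B assay, with a stated time of 48 h; on this read-out higher numbers stand for weaker inhibition and lower numbers for stronger inhibition:
compound 1, `COc1ccc(C(=O)/C=C\Nc2ccc(-c3nc4cc(OC)c(OC)c(OC)c4s3)cc2)cc1[N+](=O)[O-]`, gives 17100 nM
compound 2, `COc1ccc(C(=O)/C=C\Nc2ccc(-c3nc4cc(OC)c(OC)c(OC)c4s3)cc2)cc1O`, gives 18100 nM
compound 3, `COc1cc(C(=O)/C=C\Nc2ccc(-c3nc4cc(OC)c(OC)c(OC)c4s3)cc2)cc([N+](=O)[O-])c1OC`, gives 9800 nM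

Compound 3 holds the lowest of the three numbers, yet its gaps to compound 1 and to compound 2 both fall inside the scatter, so no ranking among the three can be read from these numbers.

Compound 4, `COc1cc(C(=O)/C=C\Nc2ccc(-c3nc4cc(OC)c(OC)c(OC)c4s3)cc2)cc(OC)c1OC`, is not yet measured. It differs from compound 3 by methoxy in place of nitro on an aromatic carbon.

Going by the values given here, two measured steps bear on this change. Removing the nitro for hydroxy, a 1.1-fold higher number from compound 1 to compound 2 (0.02 log units; within the scatter), was flat. Adding a methoxy, a 1.7-fold lower number from compound 1 to compound 3 (0.24 log units; within the scatter), was also inside the scatter. Neither the loss of the nitro nor the gain of a methoxy has so far moved this assay beyond its noise, so compound 4 is expected to sit near compound 3, with a step of a 1.2-fold lower number from compound 3 to compound 4 (0.09 log units; within the scatter) that stays within the scatter.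

The estimate for compound 4 in this assay is therefore 8000 nM, with a range from 2500 nM to 25000 nM.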

Compound 4, half-maximal inhibitory concentration: 16500 nM
Compound 4: middle estimate off by 2.1-fold (0.31 log units), on the low side, and the stated range covers the measured number.
By their numbers in this assay, from the lowest: compounds 3, 4, 1 and 2 (each within the scatter of the next).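

In this assay, methoxy in place of nitro, on the carbon ortho to a methoxy group, gives a 1.7-fold higher number from compound 3 to compound 4 (0.23 log units; within the scatter) and so leaves this position without a step beyond the scatter. The wider exchanges read the same way, with 3,4,5-trimethoxyphenyl in place of 3-hydroxy-4-methoxyphenyl giving a 1.1-fold lower number from compound 2 to compound 4 (0.04 log units; within the scatter) and the same group in place of 4-methoxy-3-nitrophenyl giving a 1.0-fold lower number from compound 1 to compound 4 (0.02 log units; within the scatter) as well, so nitro, hydroxy and methoxy are not told apart by these four compounds. No measurement to hand explains this flat picture.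

Going by these compounds, whether an amine or a carboxylic acid at this position would give a step beyond the scatter remains open. So does whether a longer chain in place of the methoxy would do so.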